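This account rests on a few compounds, and the source may have more. Where it says the series, first, only, none or still open, it means among the compounds named here.

Measured compounds in a functional assay on MCF7 cells (Homo sapiens) for inhibition, read by MTT assay, with a stated time of 72 h; on this read-out lower numbers stand for stronger inhibition and higher numbers for weaker inhibition:
compound 1 `COc1ccc2c(c1)/C(=N/NC(=S)N1CCN(c3ccccc3)CC1)C(=O)N2` gives 14400 nM
compound 2 `O=C1Nc2cc(Cl)ccc2/C1=N/NC(=S)N1CCN(c2ccccc2)CC1` gives 23000 nM
compound 3 `Cc1ccc(N2CCN(C(=S)N/N=C3\C(=O)Nc4ccc(Cl)cc43)CC2)c(C)c1` gives 10800 nM

Compound 3 has the lowest of the three numbers. Its nearest neighbour is compound 1, whose number is within the scatter of it, so no order between compound 3 and compound 1 can be read. Compound 2 lies furthest from compound 3, beyond the scatter, so compound 3 is the stronger inhibitor of that pair.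

Compound 4 `O=C1Nc2ccc(Cl)cc2/C1=N/NC(=S)N1CCN(c2ccc([N+](=O)[O-])cc2)CC1` is the unmeasured analogue: 4-nitrophenyl in place of 2,4-dimethylphenyl on an amine nitrogen in a ring. Within the data shown here, no step between measured compounds covers this change. Given that the three measured numbers span little, compound 4 is expected to stay near compound 3, with the step of a 1.4-fold higher number from compound 3 to compound 4 (0.14 log units; within the scatter) expected to lie within or barely beyond the scatter. Compound 4 is estimated at 15000 nM, range 6000 nM to 40000 nM.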

Compound 4, half-maximal inhibitory concentration: 20900 nM
Beside the measured number, compound 4's estimate is 1.4-fold (0.14 log units) below it, and the stated range covers the measured number.
By their numbers in this assay, from the lowest: compounds 3, 1, 4 and 2 (each within the scatter of the next, the first and the last beyond it).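

In this assay, the group on the ring amine nitrogen gets its first one-place reading: 4-nitrophenyl in place of 2,4-dimethylphenyl gives a 1.9-fold higher number from compound 3 to compound 4 (0.29 log units; within the scatter) as the step. At this position, then, the two substituted phenyl groups cannot be told apart, although their substituents share nothing. Nothing at hand explains this result.

Open, as far as these compounds go, is whether an aminophenyl, a pyridine ring or a saturated cyclohexyl ring on this nitrogen would move the number beyond the scatter. Also open, from the compounds shown here alone, is whether a carboxylic acid on the phenyl ring would do so.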